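The compounds below may be only part of what the source reports. "The series", "measured", "known", "first", "only" and "open" are said of these compounds alone.

Measured in an ADME assay on J774 cells (Mus musculus) for antiproliferative activity, with a stated time of 72 h; on this read-out higher numbers stand for an effect only at larger amounts of compound and lower numbers for an effect already at smaller amounts:
- compound 1 `CCCCc1cc2c(=O)c(-c3ccc(C)cc3C)c(C)[nH]c2cc1OCCOc1ccccc1`: 22000 nM
- compound 2 `CCCCc1cc2c(=O)c(-c3ccc(C(F)(F)F)cc3F)c(C)[nH]c2cc1OCCOc1ccccc1`: 19000 nM

Compound 2 stands within the scatter of compound 1, so the two values give no order. Compound 3 `CCCCc1cc2c(=O)c(-c3ccc(Cl)cc3C)c(C)[nH]c2cc1OCCOc1ccccc1` carries 4-chloro-2-methylphenyl in place of 2-fluoro-4-(trifluoromethyl)phenyl on an aromatic carbon. Going by the values given here, one measured step bears on this place: a 1.2-fold lower number from compound 1 to compound 2 (0.06 log units; within the scatter), an exchange of the same aryl group that stayed within the scatter. In this assay the expected step is a 1.1-fold higher number from compound 2 to compound 3 (0.02 log units; within the scatter), with nothing expected beyond the scatter. Compound 3 is estimated at 20000 nM, with an expected range of 10000 nM to 40000 nM.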

Compound 3, half-maximal effective concentration: > 21000 nM
Compound 3: a limit, no number (the forecaster's own chance of this, stated with the estimate: 15%); middle value at least 1.0-fold (0.02 log units) away from the limit.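

In this assay compound 3 gives only a limit, > 21000 nM, not a number. For 4-chloro-2-methylphenyl in place of 2-fluoro-4-(trifluoromethyl)phenyl, the data give an at least 1.1-fold higher number from compound 2 to compound 3 (0.04 log units; that floor lies within the scatter), so this change has a floor and no measured size. The step for chloro in place of methyl cannot be read, and the top of the range at this position stays undefined: the limit of > 21000 nM in this assay, at which 1 of the 3 values shown sits.

As far as these compounds go, whether any aryl exchange here moves the value beyond the scatter stays open. So does how an amine or a carboxylic acid on this aryl ring would read in this assay.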